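The source may hold more compounds than are shown below. What is called first, only, known or untested is meant among the compounds shown, and "the series" means these compounds.

Measured so far:
- compound 1, `CCN(CC)CCCn1c(=O)c(=Cc2ccc(F)cc2F)s/c1=C1\C(=O)Nc2ccc(Cl)cc21`: in a functional assay on HT-29 cells (Homo sapiens) for inhibition, read by MTT assay, with a stated time of 72 h (on this read-out higher numbers stand for weaker inhibition and lower numbers for stronger inhibition), compound 1 gives > 200000 nM, a limit of the assay rather than a number.
- compound 2, `COc1ccc(C=c2s/c(=C3\C(=O)Nc4cc(F)ccc43)n(CCN(C)C)c2=O)cc1`: in this assay compound 2 gives 2300 nM.

Compound 2 thus holds the only actual number shown; the other result is the limit at which compound 1 sits, (the limit of > 200000 nM in this assay, at which 1 of the 2 values shown sits). Compound 3, `CN(C)CCn1c(=O)c(=Cc2ccc(F)cc2F)s/c1=C1\C(=O)Nc2cc(F)ccc21`, has not been measured. It differs from compound 2 in one place: 2,4-difluorophenyl in place of 4-methoxyphenyl on a double-bonded chain carbon bound to an aromatic carbon. Within the data shown here, no pair of measured compounds differs in only one place, so no measured step guides this change directly. Compound 1 also carries a 2,4-difluorophenyl group and reaches only the limit, whereas compound 2 gives a number, but compound 1 differs from both in more than this one group. On that thin basis a weakening is expected from compound 2 to compound 3, a 6.5-fold higher number from compound 2 to compound 3 (0.81 log units; beyond the scatter). Compound 3 is therefore estimated at 15000 nM, likely between 3000 nM and 100000 nM.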

Compound 3, half-maximal inhibitory concentration: 6460 nM
The estimate for compound 3 lay 2.3-fold (0.37 log units) above the measured number; measured number inside the range.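

In this assay, among these compounds, replacing 4-methoxyphenyl with 2,4-difluorophenyl on a double-bonded chain carbon bound to an aromatic carbon gives a 2.8-fold higher number from compound 2 to compound 3 (0.45 log units; beyond the scatter) and is the only measured change here made in a single place. The step is modest, and compound 3 gives 6460 nM and not a limit, so this place accepts a ring with two fluorines instead of a methoxy group while inhibition remains measurable. Nothing measured here shows which part of the change sets the size of this step.

The compounds shown leave open how a plain phenyl, a pyridine ring, or a phenyl ring carrying an amine or a carboxylic acid would behave at this carbon. They also leave open whether the step would keep its size on a compound with a longer chain in place of the dimethylaminoethyl chain.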